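A Protected Lysine Side Chain in Place of Guanidine

The source may report more compounds than this note shows. Statements on the series, on what has been measured and on what is new or still open speak of the compounds shown alone.

For the measured compounds named here, compound 1, `N=C(N)NCCC[C@H](NC(=O)CN(c1ncnc2c1ncn2C1CCCCO1)C1CC1)C(=O)OCc1ccccc1`, stands highest of the two compounds measured so far. In a functional assay on the whole organism (Tail, strain ICR) with Mus musculus as the target, in the tail flick test, with a stated time of 120 min, at a dose of 25 umol/kg by the oral route (on this read-out higher numbers stand for a stronger effect at the one dose given and lower numbers for a weaker effect), compound 1 gives 38.2%. Compound 2, `O=C(CN(c1nc(Cl)nc2[nH]cnc12)C1CC1)N[C@@H](CC(=O)OCc1ccccc1)C(=O)OCc1ccccc1`, gives 12.1% in this assay, a number beyond the usual scatter below the value of compound 1. The two measured compounds differ in more than one place, so no single structural change has yet been followed from one measured value to another.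

Compound 3, `CC(C)(C)OC(=O)NCCCC[C@H](NC(=O)CN(c1ncnc2c1ncn2C1CCCCO1)C1CC1)C(=O)OCc1ccccc1`, is reached from compound 1 by one change: a group of 9 heavy atoms (6 carbon, 1 nitrogen, 2 oxygen; no ring) in place of a group of 4 heavy atoms (1 carbon, 3 nitrogen; no ring), on a saturated chain carbon, four bonds along the chain from an amide-type nitrogen and a carbonyl carbon. The group of 4 heavy atoms (1 carbon, 3 nitrogen) that leaves carries three hydrogen-bond donors, while the ((tert-butoxycarbonyl)amino)methyl group that enters carries one hydrogen-bond donor and two hydrogen-bond acceptors.

Going by the values given here, with no measured one-place step to lean on, the expectation rests on the starting value of compound 1 in this assay, which is 38.2%, and on the size of the change. A downward shift beyond the scatter is expected, as the step of a number 16.2 percentage points lower from compound 1 to compound 3 (beyond the scatter) in this assay shows. Compound 3 is therefore estimated to give 22% in this assay, most likely between 8% and 40%.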

Compound 3, a percentage reported as activity, at one dose (the size of the read-out at that dose, not a potency): 28.4%
Compound 3: the middle estimate sits 6.4 percentage points below what was measured; the range from low to high includes it.
By their numbers in this assay, from the lowest: compound 2; then compounds 3 and 1 (each within the scatter of the next).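

For the compounds shown here, this is the first one-place step that can be read in this assay, and it comes out as a number 9.8 percentage points lower from compound 1 to compound 3 (within the scatter). The ((tert-butoxycarbonyl)amino)methyl group that enters is larger than the group that leaves and carries fewer hydrogen-bond donors, yet at this position, on a saturated chain carbon, the two values stay within the scatter of each other, so this swap gives no readable difference at the one dose tested. The data offer nothing that would explain this result.

The compounds shown leave open whether a simple amine or a carboxylic acid at this same place would also stay within the scatter of compound 1, and whether a longer chain would do so. A read-out at one dose and one time point also leaves open whether compound 1 and compound 3 would remain this close at other doses or at other times after dosing.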